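Chloro Added to the Hydroxyphenyl Ring of Compound 1

The source may report more compounds than this note shows. Statements on the series, on what has been measured and on what is new or still open speak of the compounds shown alone.

Compound 1 `COc1ccc(C2=NN(C(=O)CN3CCCCC3)C(c3ccccc3O)C2)cc1`, compound 2 `O=C(CN1CCCCC1)N1N=C(c2ccccc2)CC1c1ccccc1O` and compound 3 `O=C(CN1CCCCC1)N1N=C(c2ccc(Cl)cc2)CC1c1ccccc1O` share one core and differ in a single aromatic substituent. Compound 1 differs from compound 2 by methoxy in place of hydrogen on an aromatic carbon, and compound 3 differs from compound 2 by chloro in place of hydrogen on an aromatic carbon, a change on a carbon para to a large group, reading phenyl to 4-chlorophenyl. In an assay on isolated protein for inhibition of Amine oxidase [flavin-containing] A (Homo sapiens), read by fluorescence, with stated times of 15 min and 20 min (on this read-out lower numbers stand for stronger inhibition and higher numbers for weaker inhibition), compound 1 gives 12700 nM, compound 2 gives 9510 nM and compound 3 gives 7250 nM. The steps of a 1.3-fold lower number from compound 1 to compound 2 (0.13 log units; within the scatter), a 1.8-fold lower number from compound 1 to compound 3 (0.24 log units; within the scatter) and a 1.3-fold lower number from compound 2 to compound 3 (0.12 log units; within the scatter) all stay within the scatter, so none of the three can be set apart from the others.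

Compound 4 `COc1ccc(C2=NN(C(=O)CN3CCCCC3)C(c3cc(Cl)ccc3O)C2)cc1` has not been measured. It differs from compound 1 by chloro in place of hydrogen on an aromatic carbon, where the chloro enters meta to a large group and para to a hydroxy group, so this is the same kind of change as the earlier one, not the same change. Resting on a 1.3-fold lower number from compound 2 to compound 3 (0.12 log units; within the scatter), the expected step is a 1.3-fold lower number from compound 1 to compound 4 (0.13 log units; within the scatter). Compound 4 is estimated to give about 9500 nM in this assay, most likely between 4000 nM and 22000 nM.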

Compound 4, half-maximal inhibitory concentration: 9650 nM
For compound 4 the middle estimate is 1.0-fold (0.01 log units) below the measured one; the range from low to high includes it.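

In this assay, chloro in place of hydrogen on the core of compound 1 gives a 1.3-fold lower number from compound 1 to compound 4 (0.12 log units; within the scatter), and this step has the same size as the one seen on the other core: the same change on two cores in this assay, a 1.3-fold lower number (0.12 log units; within the scatter) from compound 2 to compound 3 and a 1.3-fold lower number (0.12 log units; within the scatter) from compound 1 to compound 4, 1.0-fold (0.00 log units) apart, within the scatter of two such steps. Among these compounds, both steps lie within the scatter, so the match shows only that this swap left the number indistinguishable from that of the parent compound on each of the two cores; it does not show a real gain that carries from one core to the other. The chloro also sits in a different place in each pair, on the phenyl ring going to compound 3 and on the 2-hydroxyphenyl ring going to compound 4, and two small steps cannot support a general rule.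

Still open, going by these compounds, is whether any group at the place taken by chloro in compound 4 would move the number beyond the scatter, for instance an amine or a carboxylic acid. The effect of chloro on both aromatic rings at once is also unknown.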